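Lengthening the thioether chain by one more carbon

A few compounds are considered here, and "the series" means these few. Any claim that something is new, unique, unknown or untested is made for them only; others in the source may bear on it.

Three measured compounds share one core and differ only in the length of a saturated chain attached through a sulfur. Compound 1 is `CCCCCCCSC[C@H](NC(C)=O)C(=O)CCl`, compound 2 is `CCCCCCCCCSC[C@H](NC(C)=O)C(=O)CCl` and compound 3 is `CCCCCCCCCCCCCSC[C@H](NC(C)=O)C(=O)CCl`. In a functional assay on NALM-6 cells (Homo sapiens) (on this read-out higher numbers stand for weaker inhibition and lower numbers for stronger inhibition), compound 1 gives 4800 nM. In this assay compound 2 gives 7300 nM. For compound 3 this assay reports no number but only a limit, > 100000 nM. Compound 3 therefore stands at the limit of > 100000 nM in this assay, at which 1 of the 3 values shown sits, the weak end of what was measured. The step of a 1.5-fold higher number from compound 1 to compound 2 (0.18 log units; within the scatter) is small, while the steps of an at least 20-fold higher number from compound 1 to compound 3 (1.31 log units; beyond the scatter) and an at least 13-fold higher number from compound 2 to compound 3 (1.13 log units; beyond the scatter) are both large.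

Compound 4 is `CCCCCCCCCCCCCCSC[C@H](NC(C)=O)C(=O)CCl`, and it differs from compound 3 by methyl in place of hydrogen on a saturated chain carbon, ten or more bonds along the chain from a sulfur. The two large steps, each of which lengthened the same chain, both moved the number sharply upward, so a further lengthening is expected to give, if anything, a still higher number, and most likely this assay will again report only a limit. Compound 4 is expected to give about 150000 nM in this assay, with a range from 60000 nM to 500000 nM. This estimate means an expected step that the limit leaves unreadable from compound 3 to compound 4, not resolved beyond the limit.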

Compound 4, half-maximal inhibitory concentration: 8700 nM
Estimate against measurement, compound 4: 17-fold (1.24 log units) above; measured number outside the range, below it.
By their numbers in this assay, from the lowest: compounds 1, 2 and 4 (each within the scatter of the next). At a limit, above all of these: compound 3.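

A single added methyl on a saturated chain carbon gives an at least 11-fold lower number from compound 3 to compound 4 (1.06 log units; beyond the scatter) in this assay, so the sharp loss at compound 3 does not carry on as the chain grows. For the compounds shown here, the earlier compounds suggested that lengthening the chain steadily weakens inhibition, yet the chain of compound 4 reads like the shorter ones, with a 1.2-fold higher number from compound 2 to compound 4 (0.08 log units; within the scatter) and a 1.8-fold higher number from compound 1 to compound 4 (0.26 log units; within the scatter), leaving compound 3 as the one compound that goes against a flat pattern across this series. The first of these steps gives only a minimum size, and compound 3 has a limit rather than a number: the limit of > 100000 nM in this assay, at which 1 of the 4 values shown sits.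

The compounds shown leave open whether the result for compound 3 belongs to that one chain length alone or marks a narrow band of chain lengths, and how steep the change really is. Also open, from the compounds shown here alone, is how a still longer chain, or a chain carrying an amine or a carboxylic acid, would read in this assay.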